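The compounds below may be only part of what the source reports. "The series", "measured", "known", "first", "only" and "open" are said of these compounds alone.

Compound 1 `CC1=CC[C@H](C(C)(C)NC(=S)N/N=C/c2ccccc2)CC1` gives in a functional assay on NCI/ADR-RES cells (Homo sapiens) for inhibition, read by sulforhodamine B assay, with a stated time of 48 h (a higher number here means a weaker inhibitor of growth, a lower number a stronger inhibitor of growth), only a limit, namely > 100000 nM. Compound 2 `CC1=CC[C@H](C(C)(C)NC(=S)N/N=C/c2ccccc2Cl)CC1` likewise gives in this assay a limit, > 100000 nM. The step between them, a step that the two limits leave unreadable from compound 1 to compound 2, is unreadable in size, both values sitting at the limit of > 100000 nM in this assay, at which 2 of the 2 values shown sit. Compound 1 thus stands only at a limit in this assay, with no number placing it. Compound 3 `CC1=CC[C@H](C(C)(C)NC(=S)N/N=C/c2cccc(Cl)c2)CC1` carries the change (chloro in place of hydrogen on an aromatic carbon). Among the compounds with values here, the only measured step bearing on it is a step that the two limits leave unreadable from compound 1 to compound 2, which reads nothing. Within the data shown here, the change is expected to give a step that the limit leaves unreadable from compound 1 to compound 3, no step readable beyond scatter. Compound 3 is accordingly estimated at 150000 nM in this assay, within 50000 nM to 500000 nM, most probably again only a limit.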

Compound 3, concentration for total growth inhibition: > 100000 nM
Compound 3 was reported as a limit; the forecaster's own chance of this, stated with the estimate: 80%; the middle value lies beyond the limit too.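

Compound 3 is again only a limit, so its steps from compound 1 and compound 2 cannot be read: the limit of > 100000 nM in this assay, at which 3 of the 3 values shown sit. The compounds shown leave open where any of the three truly stands in this assay, and what chloro in place of hydrogen does there.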